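Compound 3 to compound 4: one group exchanged

The source may hold more compounds than are shown below. What is called first, only, known or untested is meant among the compounds shown, and "the series" means these compounds.

Compound 1 `O=C(CCc1cccc2c1B(O)OC2)Nc1ccccc1` is the plainest of three related molecules, and in a functional assay on MDA-MB-231 cells (Homo sapiens) for antiproliferative activity, read by MTT assay, with a stated time of 72 h (on this read-out higher numbers stand for weaker inhibition and lower numbers for stronger inhibition), compound 1 gives 230 nM. Compound 2 `O=C(CCc1cccc2c1B(O)OC2)Nc1ccc(Cl)cc1`, with chloro in place of a hydrogen on an aromatic carbon, gives 3600 nM. Compound 3 `CC(C)(C)OC(=O)Nc1ccc(NC(=O)CCc2cccc3c2B(O)OC3)cc1`, with (tert-butoxycarbonyl)amino there instead, gives 29000 nM, the highest number of the three and so the weakest inhibition.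

Compound 4 `CCOC(=O)c1ccc(NC(=O)CCc2cccc3c2B(O)OC3)cc1` differs from compound 3 by one exchange: ethoxycarbonyl in place of (tert-butoxycarbonyl)amino on an aromatic carbon, para to a large group (ethoxycarbonyl in place of (tert-butoxycarbonyl)amino on an aromatic carbon).

Among the measured compounds shown here, three measured steps bear on this exchange. The chloro step was large, a 16-fold higher number from compound 1 to compound 2 (1.19 log units; beyond the scatter). The (tert-butoxycarbonyl)amino step was larger still, a 130-fold higher number from compound 1 to compound 3 (2.10 log units; beyond the scatter). Exchanging these two groups was a modest step, an 8.1-fold higher number from compound 2 to compound 3 (0.91 log units; beyond the scatter). Both groups raised the number, but by different amounts, so the group chosen matters. For the measured compounds named here, no measured compound carries ethoxycarbonyl, which makes any forecast uncertain. A position near compound 2 seems the most reasonable guess, well above compound 1 but below compound 3. A modest drop in the number is therefore expected, an estimated 4.8-fold lower number from compound 3 to compound 4 (0.68 log units; beyond the scatter). In this assay the expected value for compound 4 is 6000 nM, with an estimated range from 1500 nM to 25000 nM.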

Compound 4, half-maximal inhibitory concentration: > 100000 nM
Compound 4 was reported as a limit (the forecaster's own chance of this, stated with the estimate: 5%); at least 16-fold (1.22 log units) between middle value and limit.
By their numbers in this assay, from the lowest: compound 1; then compound 2; then compound 3. At a limit, above all of these: compound 4.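

In this assay compound 4 is reported only as a limit, not as a number: the limit of > 100000 nM in this assay, at which 1 of the 4 values shown sits.

Read with that limit, the steps are an at least 3.4-fold higher number from compound 3 to compound 4 (0.53 log units; beyond the scatter), an at least 27-fold higher number from compound 2 to compound 4 (1.44 log units; beyond the scatter) and an at least 430-fold higher number from compound 1 to compound 4 (2.63 log units; beyond the scatter), so all three earlier compounds inhibit more strongly than compound 4, and every substituent shown here gives a higher number than the hydrogen of compound 1. Among compounds 1, 2 and 3, the number rose from hydrogen through chloro to the large (tert-butoxycarbonyl)amino group, which could have suggested that bigger groups on this aromatic carbon simply cost more, but compound 4 goes against that reading, since ethoxycarbonyl has fewer heavy atoms than the group it replaces and still gives the weakest result of the four.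

Compounds 3 and 4 also differ in hydrogen-bond donors, with one in the group that leaves and none in the group that enters, so size and donor count change together and these compounds cannot separate them. On these data alone, how a free amine, a carboxylic acid or a simple methyl group would behave on this same carbon remains open.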